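Swapping a Benzyl for a Methoxycarbonyl on the Tetrazole

A few compounds are considered here, and "the series" means these few. Any claim that something is new, unique, unknown or untested is made for them only; others in the source may bear on it.

Measured so far:
- Compound 1, `CCCCCCCCc1ccc(OCC(=O)Cn2nnc(C(=O)OC)n2)cc1`: 88 nM
- Compound 2, `CCCCCCCCc1ccc(OCC(=O)Cn2nnnc2Cc2ccccc2)cc1`: 320 nM

Both compounds were tested in an assay on microsomes from brain for inhibition of Fatty-acid amide hydrolase 1 (Rattus norvegicus), read by fluorescence and HPLC, with a stated time of 60 min; a lower number here means a stronger inhibitor, a higher number a weaker inhibitor. Compound 1 gives 88 nM, while compound 2 gives 320 nM, the higher of the two numbers and therefore the weaker inhibitor; the gap between them lies beyond the usual scatter of repeated measurements.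

Compound 3, `CCCCCCCCc1ccc(OCC(=O)Cn2nnnc2C(=O)OC)cc1`, has not yet been measured. It differs from compound 2 in one place: methoxycarbonyl in place of benzyl on an aromatic carbon. The same methoxycarbonyl group appears in compound 1, though attached at a different point of the shared core, so the pair of measured values gives only an indirect hint of what this change does.

Because compound 1 reaches 88 nM with a methoxycarbonyl group present, compound 3 is expected to land nearer that value than compound 2 does, so the step from compound 2 to compound 3 is estimated at a 2.7-fold lower number from compound 2 to compound 3 (0.43 log units; beyond the scatter), toward a lower number. The estimate for compound 3 in this assay is 120 nM, with a likely range from 40 nM to 400 nM.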

Compound 3, half-maximal inhibitory concentration: 1000 nM
The estimate for compound 3 lay 8.3-fold (0.92 log units) below the measured number, and the stated range ends below it.
By their numbers in this assay, from the lowest: compound 1; then compound 2; then compound 3.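

In this assay, methoxycarbonyl on the aromatic carbon of the five-membered ring with 4 nitrogen does not carry the strength of compound 1 with it: replacing benzyl there gives a 3.1-fold higher number from compound 2 to compound 3 (0.49 log units; beyond the scatter), so at this position the group with the six-membered aromatic ring gives the stronger inhibitor of the two. The second step is the more telling one, since compound 1 and compound 3 carry the same methoxycarbonyl group and differ only in how the ring is joined to the saturated chain carbon: going from the 5-(methoxycarbonyl)-2H-tetrazol-2-yl form to the 5-(methoxycarbonyl)-1H-tetrazol-1-yl form gives an 11-fold higher number from compound 1 to compound 3 (1.06 log units; beyond the scatter), a large change with no atom added or lost. So in this pair the arrangement of the ring matters, not just the presence of the group, though no measurement shown here explains why either step occurs.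

Still open, on these data alone, is how benzyl behaves on the 2H-tetrazol-2-yl form, which would show whether the order of the two groups holds for both ways of joining the ring. Also open, as far as these compounds go, is how a carboxylic acid or an amide would compare with methoxycarbonyl at this position.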